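This account rests on a few compounds, and the source may have more. Where it says the series, first, only, none or still open, it means among the compounds named here.

Working notes on the series. Compound 1 `Nc1sc(-c2ccccc2)c(-c2ccc(Cl)cc2)c1C(=O)NC1CC1` and compound 2 `Nc1sc(-c2ccccc2)c(-c2ccc(Cl)cc2)c1C(=O)N1CCCC1` are both amides; in a functional assay on PC-3 cells (Homo sapiens) for cytotoxicity, read by sulforhodamine B assay, with a stated time of 72 h (on this read-out higher numbers stand for weaker inhibition and lower numbers for stronger inhibition), compound 1 gives 17100 nM and compound 2 gives 22200 nM. For the measured compounds named here, the single step between them, a 1.3-fold higher number from compound 1 to compound 2 (0.11 log units; within the scatter), shows that exchanging one amide substituent for another leaves the read-out essentially unchanged. Compound 3 `COC(=O)c1c(N)sc(-c2ccc(Cl)cc2)c1-c1ccc(Cl)cc1` is the methyl ester and gives 2780 nM in this assay, the lowest number of the three and beyond the scatter from both compound 1 and compound 2.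

Compound 4 `Nc1sc(-c2ccc(Cl)cc2)c(-c2ccc(Cl)cc2)c1C(=O)NC1CCCCC1` keeps the core of compound 3 and differs only at the carbonyl: cyclohexylamino in place of methoxy on a carbonyl carbon. Going by the values given here, no measured step covers an ester-to-amide change on an otherwise identical core; compound 1 and compound 2 carry a different aryl group, so their gap to compound 3 mixes two changes. What the numbers do show is that both amides sit at higher numbers than the ester, while the amide variation within them lies inside the scatter. On that basis a moderate shift toward a higher number is expected for compound 4, as a 3.2-fold higher number from compound 3 to compound 4 (0.51 log units; beyond the scatter) in this assay, though the confounded comparison leaves the size uncertain. The estimate for compound 4 in this assay is 9000 nM, with a range from 2500 nM to 30000 nM.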

Compound 4, half-maximal inhibitory concentration: 7300 nM
For compound 4 the middle estimate is 1.2-fold (0.09 log units) above the measured one; the measured number falls inside the stated range.
By their numbers in this assay, from the lowest: compound 3; then compound 4; then compounds 1 and 2 (each within the scatter of the next).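

On the core of compound 3, the change at this carbonyl carbon can now be read by itself: a 2.6-fold higher number from compound 3 to compound 4 (0.42 log units; beyond the scatter) in this assay, a modest shift that lies beyond the scatter. The earlier amides could not show this, since compound 1 and compound 2 also differ from compound 3 in an aryl group, whereas here methoxy gives way to cyclohexylamino and the rest of the structure stays the same. Nothing in the available data accounts for the shift, and no supporting measurement bears on it.

A single pair cannot separate the effect of turning the methoxycarbonyl into a cyclohexylcarbamoyl linkage from the effect of the cyclohexyl ring itself, and a primary carboxamide or a methylamino group on the same carbonyl carbon would help to divide the two. Also open, on these data alone, is how the free carboxylic acid would read on this core, and whether cyclopropylamino and pyrrolidin-1-yl, which stay within the scatter of each other at a 1.3-fold higher number from compound 1 to compound 2 (0.11 log units; within the scatter), would keep that closeness here.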